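Replacing 1H-indol-6-yl in compound 1

The compounds below may be only part of what the source reports. "The series", "measured", "known", "first", "only" and "open" are said of these compounds alone.

Measured values in a functional assay on DU-145 cells (Homo sapiens) for inhibition, read by trypan blue exclusion, with a stated time of 72 h (on this read-out lower numbers stand for stronger inhibition and higher numbers for weaker inhibition), are:
compound 1 `Cc1ccc(S(=O)(=O)c2cc3cnc(Nc4ccc5cc[nH]c5c4)nc3n(C)c2=O)cc1` with 15000 nM
compound 2 `Cn1c(=O)c(S(=O)(=O)c2ccc(F)cc2F)cc2cnc(Nc3ccc4cc[nH]c4c3)nc21` with 5000 nM

Compound 1 holds the higher of these two numbers, and so the weaker inhibition. Compound 3 `Cc1ccc(S(=O)(=O)c2cc3cnc(Nc4ccc5ncccc5c4)nc3n(C)c2=O)cc1` departs from it in a single change quinolin-6-yl in place of 1H-indol-6-yl on a nitrogen on an aromatic ring on a nitrogen on an aromatic ring. Going by the values given here, the only measured step (with a 3.0-fold lower number from compound 1 to compound 2 (0.48 log units; beyond the scatter)) is modest and concerns 2,4-difluorophenyl in place of 4-methylphenyl on a sulfonyl sulfur. Among the compounds with values here, it therefore bears only loosely on this change, and no measured step covers the place where quinolin-6-yl enters. From the compounds shown here alone, with no direct evidence, no step beyond the scatter is expected in this assay, though a move in either direction remains open. The expected outcome is a 1.3-fold lower number from compound 1 to compound 3 (0.10 log units; within the scatter) as an estimate. For compound 3 the estimated value is 12000 nM (expected range 4000 nM to 30000 nM).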

Compound 3, half-maximal inhibitory concentration: 10000 nM
Compound 3: middle estimate off by 1.2-fold (0.08 log units), on the high side; measured number inside the range.
By their numbers in this assay, from the lowest: compounds 2, 3 and 1 (each within the scatter of the next, the first and the last beyond it).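

In this assay, going by these compounds alone, the first reading at this position comes from putting quinolin-6-yl in place of 1H-indol-6-yl on the nitrogen, which gives a 1.5-fold lower number from compound 1 to compound 3 (0.18 log units; within the scatter), whereas the earlier pair spoke only to the group on the sulfonyl sulfur. The group that leaves carries a hydrogen-bond donor and a five-membered aromatic ring, the group that enters carries a hydrogen-bond acceptor and a second six-membered aromatic ring, and this exchange leaves the number within the scatter. No available evidence bears on this result.

From the compounds shown here alone, it remains open how a phenyl group carrying a piperazine or a carboxylic acid would read on this nitrogen. Also open, going by these compounds, is how quinolin-6-yl would behave when paired with 2,4-difluorophenyl on the sulfonyl sulfur.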